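Swapping the Acid-Bearing Ring for a Hydroxypyrrolidine

The source may hold more compounds than are shown below. What is called first, only, known or untested is meant among the compounds shown, and "the series" means these compounds.

Compound 1 `COc1ccc(/C=C\c2cc(OC)c(OC)c(OC)c2)cc1OCc1ccc(CN2CC[C@H](C(=O)O)C2)cc1`: in a functional assay on B16-F10 cells (Mus musculus) for antiproliferative activity, read by CCK-8 assay, with a stated time of 48 h (on this read-out higher numbers stand for weaker inhibition and lower numbers for stronger inhibition), compound 1 gives 7000 nM.
Compound 2 `COc1ccc(/C=C\c2cc(OC)c(OC)c(OC)c2)cc1OCc1ccc(CN[C@H](C(=O)O)[C@H](C)O)cc1`: in this assay compound 2 gives > 10000 nM, which is a limit of the assay and not a number.
Compound 3 `COc1ccc(/C=C\c2cc(OC)c(OC)c(OC)c2)cc1OCc1ccc(CN2CCCC[C@H]2C(=O)O)cc1`: in this assay compound 3 gives > 10000 nM, again a limit and not a number.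

Compound 3 therefore stands only at the limit of > 10000 nM in this assay, at which 2 of the 3 values shown sit, with no measured number of its own. The steps that reach it tell little: an at least 1.4-fold higher number from compound 1 to compound 3 (0.15 log units; that floor lies within the scatter), and likewise an at least 1.4-fold higher number from compound 1 to compound 2 (0.15 log units; that floor lies within the scatter), both resting on a floor that the scatter covers. Between the two limits, a step that the two limits leave unreadable from compound 2 to compound 3.

Compound 4 `COc1ccc(/C=C\c2cc(OC)c(OC)c(OC)c2)cc1OCc1ccc(CN2CC[C@@H](O)C2)cc1` is the next member, and it differs from compound 3 in one place: 3-hydroxypyrrolidin-1-yl in place of 2-carboxypiperidin-1-yl on a saturated chain carbon bound to an aromatic carbon. Within the data shown here, no measured step sets a hydroxy-bearing ring against a carboxy-bearing one, so none bears directly on this change; the only step touching the ring itself is the one from compound 1 to compound 3, and its size is not readable beyond the floor.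

Among the measured compounds shown here, the expectation for compound 4 can rest only on the weak level of the whole set, where the single number is that of compound 1. Compound 4 is expected to give about 6000 nM, within roughly 1500 nM to 20000 nM. That estimate means a step of an at least 1.6-fold lower number from compound 3 to compound 4 (0.22 log units; that floor lies within the scatter), and it is expected with wide uncertainty.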

Compound 4, half-maximal inhibitory concentration: > 10000 nM
Compound 4: no number, only a limit; the forecaster's own chance of this, stated with the estimate: 35%; middle value at least 1.6-fold (0.22 log units) from the limit.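

In this assay compound 4 adds one more limit and no number, so the set gathers further at the same ceiling: the limit of > 10000 nM in this assay, at which 3 of the 4 values shown sit.

What is new is that this ceiling is not confined to groups carrying a carboxylic acid, since a 3-hydroxypyrrolidin-1-yl group on the saturated chain carbon bound to an aromatic carbon also ends at a limit. Set against the only measured number in the set, replacing the 3-carboxypyrrolidin-1-yl group gives an at least 1.4-fold higher number from compound 1 to compound 4 (0.15 log units; that floor lies within the scatter), so no change beyond the scatter can be claimed, and the steps to compound 4 from compound 2 and compound 3 cannot be read, with limits at both ends.

The compounds shown leave open whether any group at this place can give a clear gain over compound 1, which gives 7000 nM. They also leave open whether a plain amine without hydroxy or carboxylic acid, such as dimethylamino, or a morpholine ring on the same carbon would give a measurable number in this assay.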